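Trimming the Sulfonyl Chain: Isopropyl to Ethyl

The source may report more compounds than this note shows. Statements on the series, on what has been measured and on what is new or still open speak of the compounds shown alone.

The measured compounds are:
compound 1 `CC(C)S(=O)(=O)c1ccccc1NCC1=NCCN1`, 2690 nM
compound 2 `CSc1ccc(Cl)cc1NCC1=NCCN1`, 18.6 nM
compound 3 `CS(=O)(=O)c1c(F)cccc1NCC1=NCCN1`, 550 nM

In an assay for binding affinity to Alpha-1A adrenergic receptor (Homo sapiens), read by radioligand binding (on this read-out higher numbers stand for weaker inhibition and lower numbers for stronger inhibition), compound 1 gives 2690 nM, the highest of the three numbers. Its nearest neighbour is compound 3 at 550 nM, a gap beyond the scatter, and compound 2 at 18.6 nM lies furthest away, also beyond the scatter. Compound 3 carries a methylsulfonyl group where compound 1 carries an isopropylsulfonyl group, and its number is lower; compound 2 carries a methylthio group and gives the lowest number shown.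

The unmeasured compound 4 `CCS(=O)(=O)c1ccccc1NCC1=NCCN1` differs from compound 1 in one place: hydrogen in place of methyl on a saturated chain carbon bound to a saturated chain carbon and a sulfonyl sulfur. In words, hydrogen in place of methyl on a saturated chain carbon bound to a saturated chain carbon and a sulfonyl sulfur. Among the compounds with values here, no step of this kind between measured compounds is known. Because compound 3, with the smaller methylsulfonyl group, gives 550 nM, a modest step toward a lower number is expected from compound 1 to compound 4, a 1.8-fold lower number from compound 1 to compound 4 (0.25 log units; within the scatter), possibly only just beyond the scatter. Compound 4 is therefore estimated at 1500 nM, within a range of 500 nM to 4500 nM.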

Compound 4, inhibition constant: 1200 nM
Beside the measured number, compound 4's estimate is 1.3-fold (0.10 log units) above it, within the range that was stated.
By their numbers in this assay, from the lowest: compound 2; then compound 3; then compound 4; then compound 1.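

In this assay, within the data shown here, the step that trims isopropylsulfonyl to ethylsulfonyl is a 2.2-fold lower number from compound 1 to compound 4 (0.35 log units; beyond the scatter) and gives the first reading of the chain on the sulfonyl sulfur alone. It shows that losing a single methyl at this place moves the number modestly but measurably, which compound 2 and compound 3 could not show, as each differs from compound 1 in more than one place. No measurement at hand accounts for this step.

As far as these compounds go, a single step sets no trend, so it remains open whether a propyl chain, a cyclopropyl group or a tert-butyl group on the sulfonyl sulfur would continue or break this direction. Also open, from the compounds shown here alone, is how much of the lower number of compound 2 belongs to its methylthio group and how much to its chlorine.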